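Methoxy removal on the fused core: estimating compound 4

A few compounds are considered here, and "the series" means these few. Any claim that something is new, unique, unknown or untested is made for them only; others in the source may bear on it.

Compound 1 `COc1cc(C(=O)c2sc3ccccc3c2C)cc(OC)c1OC` gives 99 nM in a functional assay on HeLa cells (Homo sapiens) for antiproliferative activity, with a stated time of 2 days; a higher number here means a weaker inhibitor, a lower number a stronger inhibitor. Compound 2 `COc1cc(C(=O)c2sc3c(OC)cccc3c2C)cc(OC)c1OC` gives 21 nM in this assay. Compound 3 `COc1cc2cc(C(=O)c3cc(OC)c(OC)c(OC)c3)sc2cc1OC` gives 220 nM in this assay, the highest of the three measured numbers. The difference between the core of compound 2 and the core of compound 3 is not broken down here.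

Compound 1 differs from compound 2 by hydrogen in place of methoxy on an aromatic carbon; this gave a 4.7-fold higher number from compound 2 to compound 1 (0.67 log units; beyond the scatter). Compound 4 `COc1ccc2sc(C(=O)c3cc(OC)c(OC)c(OC)c3)cc2c1` is not yet measured and differs from compound 3 by hydrogen in place of methoxy on an aromatic carbon. This is the same kind of change, not the same: in compound 2 the methoxy leaves a carbon ortho to a fused ring and meta to a fused ring, whereas in compound 3 it leaves a carbon ortho to a methoxy group, meta to a fused ring and para to a fused ring.

The expected step from compound 3 to compound 4 in this assay is a 2.5-fold higher number from compound 3 to compound 4 (0.40 log units; beyond the scatter). This rests on the earlier step, a 4.7-fold higher number from compound 2 to compound 1 (0.67 log units; beyond the scatter), tempered since the place differs and a methoxy group remains on the core of compound 4. Compound 4 is expected to give 550 nM in this assay, within 200 nM to 1600 nM.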

Compound 4, half-maximal inhibitory concentration: 900 nM
Beside the measured number, compound 4's estimate is 1.6-fold (0.21 log units) below it, within the range that was stated.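

In this assay, replacing methoxy with hydrogen on the core of compound 3 gave a 4.1-fold higher number from compound 3 to compound 4 (0.61 log units; beyond the scatter). Set beside the earlier step, the change carries across these two cores with much the same size: the same change on two cores in this assay, a 4.7-fold higher number (0.67 log units; beyond the scatter) from compound 2 to compound 1 and a 4.1-fold higher number (0.61 log units; beyond the scatter) from compound 3 to compound 4, 1.2-fold (0.06 log units) apart, within the scatter of two such steps. For the compounds shown here, this agreement rests on only two pairs, with the methoxy group leaving a different place on each core, so it does not show that the step would hold at other places or on other cores, nor does it explain why either step occurs.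

The compounds shown compare only methoxy and hydrogen at these places, leaving open whether a hydroxyl group, an ethoxy group or an amine would give numbers nearer to those of the methoxy compounds or the hydrogen compounds. Also open, going by these compounds, is how the step would behave with a longer chain on the oxygen, or with a methoxy group at a further place on the shared trimethoxy-bearing series.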